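The compounds below may be only part of what the source reports. "The series", "measured", "known", "first", "only" and "open" are said of these compounds alone.

Measured so far in an assay on HEK293 cells for antagonist activity at transient receptor potential cation channel subfamily V member 2 (Rattus norvegicus), read by fluorescence and calcium flux, with a stated time of 5 min; a higher number here means a weaker inhibitor, a lower number a stronger inhibitor:

Compound 1, `CCCCCCCC/C=C\CCCCCCCC[Se]C[C@H](N)C(=O)NCc1ccc(O)c(OC)c1`: compound 1 gives 980 nM
Compound 2, `CCCCCCCC/C=C\CCCCCCCC[Se]CCC(=O)NCc1ccc(O)c(OC)c1`: compound 2 gives 3200 nM
Compound 3, `CCCCCCCCCCCCCCCC(=O)NCc1ccc(O)c(OC)c1`: compound 3 gives only > 10000 nM, which is a limit of this assay and not a number.

Compound 3 therefore stands apart from the other two: compounds 1 and 2 each have a number, while compound 3 sits at the limit of > 10000 nM in this assay, at which 1 of the 3 values shown sits. Compound 4, `CCCCCCCCCCCCCCCCCCCC(=O)NCc1ccc(O)c(OC)c1`, keeps the whole of compound 3 and differs only by butyl in place of hydrogen on a saturated chain carbon, ten or more bonds along the chain from a carbonyl carbon, so the saturated chain becomes longer by that much.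

Going by the values given here, the one measured step, a 3.3-fold higher number from compound 1 to compound 2 (0.51 log units; beyond the scatter), concerns the loss of an amino group on the chain near the carbonyl, a change unrelated to chain length. Compounds 1 and 2 carry a selenium atom and a double bond in their chains, which compound 3 lacks, so their numbers give no direct guide to lengthening a plain saturated chain. Among the compounds with values here, no measured step tells how such an extension behaves here. Compound 4 is therefore expected to remain near where compound 3 stands, with an estimated value of 15000 nM and a range from 3000 nM to 60000 nM. The expected step is a step that the limit leaves unreadable from compound 3 to compound 4, and a further limit rather than a number is the more likely outcome.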

Compound 4, half-maximal inhibitory concentration: > 10000 nM
Compound 4 was reported as a limit; the forecaster's own chance of this, stated with the estimate: 65%; the middle value lies beyond the limit too.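

Compound 3 and compound 4 are each reported only as a limit of the assay and not as a number, so no step between them can be read: the limit of > 10000 nM in this assay, at which 2 of the 4 values shown sit.

The compounds shown leave open whether changing the length of a plain saturated chain has any effect on the result in this assay.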